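Swapping the Piperazine for Piperidine on a Weak Inhibitor

A few compounds are considered here, and "the series" means these few. Any claim that something is new, unique, unknown or untested is made for them only; others in the source may bear on it.

Among the measured compounds shown here, compound 3 `CN1CCN(Cc2ccc(-c3ccc(CCC(=O)c4ncc(-c5cccc(C(=O)O)n5)o4)cc3)cc2)CC1` gives 1200 nM in an assay for inhibition of Fatty-acid amide hydrolase 1 (Rattus norvegicus) (on this read-out higher numbers stand for weaker inhibition and lower numbers for stronger inhibition), the highest of the three numbers known so far. Compound 2 `CNC(=O)c1cnc(C(=O)CCc2ccc(Oc3ccccc3)cc2)o1` gives 11 nM in this assay, and compound 1 `NC(=O)c1ccc(-c2cnc(C(=O)CCc3ccc(-c4ccccc4)cc3)o2)nc1` gives 1.3 nM in this assay; both gaps to compound 3 lie well beyond the scatter. Compound 4 `O=C(O)c1cccc(-c2cnc(C(=O)CCc3ccc(-c4ccc(CN5CCCCC5)cc4)cc3)o2)n1` differs from compound 3 in one place only: piperidin-1-yl in place of 4-methylpiperazin-1-yl on a saturated chain carbon bound to an aromatic carbon. For the measured compounds named here, no measured pair shows this change, so the expectation rests on the change itself. The step of a 1.3-fold lower number from compound 3 to compound 4 (0.12 log units; within the scatter) is expected to be small, toward a lower number if anything, and probably within the scatter of repeated runs. Compound 4 is therefore estimated at 900 nM in this assay, with a range from 300 nM to 2700 nM.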

Compound 4, inhibition constant: 44 nM
Compound 4: the middle estimate sits 20-fold (1.31 log units) above what was measured; measured number outside the range, below it.
By their numbers in this assay, from the lowest: compound 1; then compound 2; then compound 4; then compound 3.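

In this assay the change from 4-methylpiperazin-1-yl to piperidin-1-yl gives a 27-fold lower number from compound 3 to compound 4 (1.44 log units; beyond the scatter) and so shows that the group on this saturated chain carbon bound to an aromatic carbon strongly affects the read-out. The earlier compounds shown here, none of which forms a one-place pair, could not show this. Nothing available accounts for the size of this step. The compounds shown leave open whether a morpholine or a diethylamino group at this place would give a number closer to that of compound 3 or compound 4.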